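This account rests on a few compounds, and the source may have more. Where it says the series, first, only, none or still open, it means among the compounds named here.

Measured so far:
compound 1 `COc1cc(-c2nnc3n2NC(c2ccco2)C(C(=O)c2ccc(C)cc2)S3)cc(OC)c1OC`
compound 2 `COc1cc(-c2nnc3n2NC(c2ccco2)C(C(=O)c2ccc(F)c(F)c2)S3)cc(OC)c1OC`
compound 3 `COc1cc(-c2nnc3n2NC(c2ccco2)C(C(=O)c2ccc([N+](=O)[O-])cc2)S3)cc(OC)c1OC`

In a functional assay on MCF7 cells (Homo sapiens) for cytotoxicity, read by MTT assay, with a stated time of 48 h (a higher number here means a weaker inhibitor, a lower number a stronger inhibitor), compound 1 gives only a limit of the assay, > 100000 nM. Compound 2 gives 73200 nM. Compound 3 likewise gives only a limit, > 100000 nM. Compound 3 thus stands at the limit, where (the limit of > 100000 nM in this assay, at which 2 of the 3 values shown sit), so compound 1 and compound 3 cannot be separated, and a step that the two limits leave unreadable from compound 1 to compound 3. The two steps that touch a number are small: an at least 1.3-fold lower number from compound 1 to compound 2 (0.13 log units; that floor lies within the scatter) and an at least 1.3-fold higher number from compound 2 to compound 3 (0.13 log units; that floor lies within the scatter); neither floor reaches beyond the scatter.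

Compound 4 `COc1cc(-c2nnc3n2NC(c2ccco2)C(C(=O)c2cccc(Br)c2)S3)cc(OC)c1OC` differs from compound 3 in one place: 3-bromophenyl in place of 4-nitrophenyl on a carbonyl carbon. Every step measured so far varies the aryl group on this same carbonyl carbon, and none of them produced a readable movement, with compound 1 and compound 3 both at the limit and compound 2 only a little inside it. The step expected here is a number no higher from compound 3 to compound 4 (the limit leaves the size open), nothing beyond the scatter in either direction, with a real chance that only a limit is reported once more. Compound 4 is therefore estimated at 100000 nM, with a range from 45000 nM to 220000 nM.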

Compound 4, half-maximal inhibitory concentration: 91800 nM
Estimate against measurement, compound 4: 1.1-fold (0.04 log units) above; the range from low to high includes it.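

Among these compounds, the step of a 1.3-fold higher number from compound 2 to compound 4 (0.10 log units; within the scatter) is the first at this carbonyl carbon with a measured number on both sides, and it lies within the scatter, so in this assay the 3,4-difluorophenyl and 3-bromophenyl groups cannot be told apart. It also shows that a number can be read with neither the nitro nor the methyl group present, though this opens no gap between the groups. Against the two compounds at the limit only floors can be read, an at least 1.0-fold lower number from compound 3 to compound 4 (0.03 log units; that floor lies within the scatter) and an at least 1.0-fold lower number from compound 1 to compound 4 (0.03 log units; that floor lies within the scatter), both within the scatter, so the four aryl groups on this carbonyl carbon show no readable movement, and the top of the range remains crowded: the limit of > 100000 nM in this assay, at which 2 of the 4 values shown sit.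

Whether any group on this carbonyl carbon can move the number beyond the scatter remains open, as all four shown are substituted phenyl rings; a phenyl ring carrying an amine or a carboxylic acid, or a longer alkyl chain in place of the aryl group, could answer that. As far as these compounds go, the rest of the shared core is the same in all four compounds, so what its parts contribute to the reading is also open.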